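This account rests on a few compounds, and the source may have more. Where it says the series, first, only, none or still open, it means among the compounds named here.

Working notes on the series, read in an ADME assay for permeability, using PAMPA, with a stated time of 4 h, at pH 7.4, tested at 100 uM; on this read-out higher numbers stand for higher permeability and lower numbers for lower permeability. Compound 1 `Cc1ccc(-c2cc3nc(C)c(C(OC(C)(C)C)C(=O)O)c(-c4cc(F)c5c(c4C)CCCO5)n3n2)cc1` gives 492 nm/s, compound 2 `Cc1nc2cc(-c3cccc(Oc4ccccc4)c3)nn2c(-c2cc(F)c3c(c2C)CCCO3)c1C(OC(C)(C)C)C(=O)O` gives 472 nm/s, and compound 3 `Cc1nc2cc(-c3cccc(-c4ccccc4)c3)nn2c(-c2cc(F)c3c(c2C)CCCO3)c1[C@H](OC(C)(C)C)C(=O)O` gives 733 nm/s. These three values lie within the scatter of one another, so compound 3 stands level with compound 1 and compound 2.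

The next entry is compound 4 `Cc1nc2cc(-c3cccc(-c4ccccc4)c3)nn2c(-c2cc(F)c3c(c2C)CCCO3)c1C(OC(C)(C)C)C(=O)O`, and its relation to compound 3 is a stereo difference only: the two compounds have the same atoms and bonds; at least one stereo element is drawn with a configuration in one of them and without one in the other: 1 of 1 stereo elements differ; a stereocentre at a saturated chain carbon is drawn S in compound 3 and without a configuration in compound 4. Within the data shown here, no step between measured compounds is available, so the series offers no direct measure of such a change. No step beyond the scatter is expected in this assay, in either direction. The expectation rests on compound 3 at 733 nm/s, whose atoms and bonds are the same as those of compound 4. The estimated step of a 1.0-fold lower number from compound 3 to compound 4 (0.02 log units; within the scatter) is expected to stay within the scatter. The estimate for compound 4 is 700 nm/s, with an expected range of 450 nm/s to 1050 nm/s.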

Compound 4, apparent permeability: 652 nm/s
Estimate against measurement, compound 4: 1.1-fold (0.03 log units) above; low and high end bracket the measured number.
By their numbers in this assay, from the lowest: compounds 2, 1, 4 and 3 (each within the scatter of the next).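

In this assay, the series now holds its first direct reading at this stereocentre, a 1.1-fold lower number from compound 3 to compound 4 (0.05 log units; within the scatter), so the number stays level whether the saturated chain carbon is drawn S or without a configuration. Compound 4 also opens two further single-place readings: phenyl in place of phenoxy on an aromatic carbon gives a 1.4-fold higher number from compound 2 to compound 4 (0.14 log units; within the scatter), and 3-phenylphenyl in place of 4-methylphenyl on an aromatic carbon gives a 1.3-fold higher number from compound 1 to compound 4 (0.12 log units; within the scatter). The stereo pair is separated by a single drawn feature: the fact that one of compounds 3 and 4 is drawn with a defined configuration and the other without, at the place where they differ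

Going by these compounds, what a compound drawn R at this carbon would give stays open, as does the make-up of the undefined material in compound 4. Also open, on these data alone, is whether an amine in place of phenyl on an aromatic carbon would give a step beyond the scatter.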